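From dimethylamino to diethylamino on the propyl chain

A few compounds are considered here, and "the series" means these few. Any claim that something is new, unique, unknown or untested is made for them only; others in the source may bear on it.

Measured so far in a functional assay on cells (Homo sapiens) for antiproliferative activity, read by MTT assay, with a stated time of 48 h (on this read-out higher numbers stand for weaker inhibition and lower numbers for stronger inhibition), for this series:
compound 1 `CN(C)CCn1c(N)c(-c2nc3cc(Cl)ccc3[nH]2)c2nc(C#N)c(C#N)nc21` gives > 50000 nM (a limit of the assay)
compound 2 `CN(C)CCCn1c(N)c(-c2nc3cc(Cl)ccc3[nH]2)c2nc(C#N)c(C#N)nc21` gives 28100 nM (a number)

Among the measured compounds shown here, compound 2 at 28100 nM holds the only actual number so far in this assay. Compound 1 is reported just as a limit of > 50000 nM in that test.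

Compound 3 `CCN(CC)CCCn1c(N)c(-c2nc3cc(Cl)ccc3[nH]2)c2nc(C#N)c(C#N)nc21` departs from compound 2 by one change diethylamino in place of dimethylamino on a saturated chain carbon, three bonds along the chain from an aromatic nitrogen in the form of diethylamino in place of dimethylamino on a saturated chain carbon, three bonds along the chain from an aromatic nitrogen.

One measured step lies close to this, an at least 1.7-fold lower number from compound 1 to compound 2 (0.25 log units; that floor lies within the scatter) and it is a different change, (dimethylamino)methyl in place of dimethylamino, resting on a limit. For the measured compounds named here, no measured step exchanges dimethylamino for diethylamino, so no step beyond the scatter is expected in this assay in either direction. The estimated change is a 1.1-fold lower number from compound 2 to compound 3 (0.05 log units; within the scatter) and it stays within the scatter. For compound 3 the expected value is 25000 nM with an estimated range from 10000 nM to 50000 nM in this test.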

Compound 3, half-maximal inhibitory concentration: 23200 nM
Estimate against measurement, compound 3: 1.1-fold (0.03 log units) above; the measured number falls inside the stated range.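

In this assay, the exchange of 3-(dimethylamino)propyl for 3-(diethylamino)propyl gives a 1.2-fold lower number from compound 2 to compound 3 (0.08 log units; within the scatter), so this first measured change at the amine itself leaves compound 2 and compound 3 indistinguishable in this test. Among the compounds shown here, measured against the 2-(dimethylamino)ethyl chain, the diethylamino compound gives an at least 2.1-fold lower number from compound 1 to compound 3 (0.33 log units; beyond the scatter), the first step printed as beyond the scatter, although it is only a floor and combines the chain and amine changes. Compound 1 is reported only as a limit, and that floor rests on it: the limit of > 50000 nM in this assay, at which 1 of the 3 values shown sits.

The compounds shown leave open whether a ring amine such as piperidine or morpholine, or a longer chain carrying the same amines, would separate from compound 2 and compound 3 in this assay. They also leave open how 2-(diethylamino)ethyl on the shared core would compare with the 2-(dimethylamino)ethyl chain of compound 1.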